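Moving a Methyl Group to a Second Ring

The compounds below may be only part of what the source reports. "The series", "measured", "known", "first", "only" and "open" are said of these compounds alone.

Measured so far, in a functional assay on the whole organism for inhibition, with Rattus norvegicus as the target, at a dose of 30 mg/kg; on this read-out lower numbers stand for less inhibition and higher numbers for more inhibition at the one dose given (going by the name of the read-out):
compound 1, `C/N=C(\S)n1ncnc1N`, gives 93%
compound 2, `C/N=C(\S)n1nc(C)nc1N`, gives 13%
compound 3, `C/N=C(\S)n1nc(-c2ccccc2)nc1N`, gives 54%

Compound 1 and compound 2 share a core and differ in one place: methyl in place of hydrogen on an aromatic carbon. That single change produced a number 80 percentage points lower from compound 1 to compound 2 (beyond the scatter). Compound 3 carries a different core; how its core differs from that of compound 1 is not broken down here. Its number sits between the other two, beyond the scatter from each of them.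

Compound 4, `C/N=C(\S)n1nc(-c2ccc(C)cc2)nc1N`, is not yet measured. It differs from compound 3 in one place: methyl in place of hydrogen on an aromatic carbon. For the measured compounds named here, this is the same kind of change as the one from compound 1 to compound 2, but not the same change. Earlier the methyl entered on a five-membered aromatic ring with 3 nitrogen, between two ring nitrogen atoms; here it enters on a six-membered aromatic ring of carbon only, para to a large group. The earlier step shows how large an effect one methyl can have, but its surroundings were different, so a smaller step is expected this time. The expectation rests on compound 3 with its value 54%, and on the size of a number 80 percentage points lower from compound 1 to compound 2 (beyond the scatter) as the largest step seen so far. Compound 4 is expected to give about 45% in this assay. The expected range for compound 4 runs from 15% to 75%. This estimate means a step of a number 9 percentage points lower from compound 3 to compound 4 (within the scatter).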

Compound 4, a percentage reported as inhibition, in the whole organism at one dose (the size of the read-out at that dose, not a potency): 65%
Estimate against measurement, compound 4: 20 percentage points below, within the range that was stated.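

In this assay, a methyl in place of a hydrogen on an aromatic carbon of a six-membered aromatic ring of carbon only gave a number 11 percentage points higher from compound 3 to compound 4 (beyond the scatter). The same kind of swap on the core of compound 1 went the opposite way, leaving compound 2 at 13%, so the effect of a methyl did not carry from one core to the other, either in size or in direction: the same change on two cores in this assay, a number 80 percentage points lower (beyond the scatter) from compound 1 to compound 2 and a number 11 percentage points higher (beyond the scatter) from compound 3 to compound 4, 91 percentage points apart, beyond the scatter of two such steps This does not show what lies behind the difference: the two methyl groups sit on different rings as well as on different cores, and two steps give no rule for any further core in this series.

The compounds shown leave open whether another group on the same aromatic carbon of compound 3, such as an ethyl group, a chlorine atom or an amine, would change the number as the methyl does, or whether the methyl result stands alone. Each number also comes from a single dose, so the compounds shown leave open how the size of the inhibition in this assay would shift at other doses, and whether the order of compound 3 and compound 4 would hold there.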